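A Second Methyl on the Aryl Ring

The compounds below may be only part of what the source reports. "The series", "measured", "known", "first", "only" and "open" are said of these compounds alone.

Compound 2 `Cc1cccc(-n2nncc2CN2C(=O)C3(C(C#N)=C(N)Oc4c(N)cc5nc6ccccc6nc5c43)c3ccccc32)c1` was tested in a functional assay on A549 cells (Homo sapiens) for antiproliferative activity, read by MTT assay, with a stated time of 48 h (a lower number here means a stronger inhibitor, a higher number a weaker inhibitor), where compound 2 gives 12300 nM. Going by the values given here, this is the only firm number in the set. Compound 1 `N#CC1=C(N)Oc2c(c3nc4ccccc4nc3c3ccccc23)C12C(=O)N(Cc1cnnn1-c1cc(Cl)ccc1Cl)c1ccccc12` reaches only a limit of the assay: in this assay compound 1 gives > 50000 nM, and the limit of > 50000 nM in this assay, at which 1 of the 2 values shown sits, records that one of the two values sits at that limit. Compound 3 `Cc1ccc(-n2nncc2CN2C(=O)C3(C(C#N)=C(N)Oc4c(N)cc5nc6ccccc6nc5c43)c3ccccc32)cc1C` has not yet been measured. It differs from compound 2 in a single spot: methyl in place of hydrogen on an aromatic carbon. Among the compounds with values here, no measured pair differing in one place is available, so there is no measured step to compare this methyl against. A change of this size would be expected to move the result little, with no step beyond the usual scatter in either direction. Compound 3 is therefore estimated at 11000 nM, with a range from 4000 nM to 30000 nM, which means an expected step of a 1.1-fold lower number from compound 2 to compound 3 (0.05 log units; within the scatter).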

Compound 3, half-maximal inhibitory concentration: > 50000 nM
Compound 3: a limit, no number; the forecaster's own chance of this, stated with the estimate: 15%; middle value at least 4.5-fold (0.65 log units) away from the limit.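

Adding one methyl to turn 3-methylphenyl into 3,4-dimethylphenyl weakens the compound in this assay, giving an at least 4.0-fold higher number from compound 2 to compound 3 (0.60 log units; beyond the scatter). Going by these compounds alone, this is the first measured step in the set, and it shows that, for this pair, the aromatic carbon ortho to a methyl group and para to a large group does not take a methyl without a loss of activity, even though the change adds only one carbon. The full size of the step remains unknown, since compound 3 sits at a limit of the assay and has no firm number: the limit of > 50000 nM in this assay, at which 2 of the 3 values shown sit.

Going by these compounds, it remains open how a fluorine atom, a hydroxyl or an amine would fare at this position. Also open, on these data alone, is how a plain phenyl ring, with no methyl at all, would compare with compound 2.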